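This account rests on a few compounds, and the source may have more. Where it says the series, first, only, none or still open, it means among the compounds named here.

Compound 3 `COc1ccc(-c2cn(-c3cccc(C(=O)/C=C/c4ccc(O)c(OC)c4)c3)c(=O)[nH]2)cc1` gives 13300 nM in a functional assay on UACC-257 cells (Homo sapiens) for inhibition (on this read-out lower numbers stand for stronger inhibition of growth and higher numbers for weaker inhibition of growth), the highest of the three numbers recorded there. Compound 1 `COc1cc(/C=C/C(=O)c2cccc(-n3cc(-c4ccccc4)[nH]c3=O)c2)ccc1O` gives 6810 nM in this assay, and the difference between them, a 2.0-fold higher number from compound 1 to compound 3 (0.29 log units; within the scatter), stays within the scatter. For the measured compounds named here, compound 2 `O=C(/C=C/c1cccc(O)c1)c1cccc(-n2cc(-c3ccc(Cl)cc3)[nH]c2=O)c1` gives 4070 nM in this assay, but it differs from compound 3 in more than one place, so its value shows only that a chloro-bearing analogue can sit lower.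

Compound 4 `COc1cc(/C=C/C(=O)c2cccc(-n3cc(-c4ccc(Cl)cc4)[nH]c3=O)c2)ccc1O` is made from compound 3 by the change (chloro in place of methoxy on an aromatic carbon). Going by the values given here, no measured step covers this exchange directly; the only single-point step, from hydrogen to methoxy, was within the scatter, and the lower number of compound 2 is the sole hint that chloro might help. Compound 4 is therefore expected to improve modestly at best, with a 2.7-fold lower number from compound 3 to compound 4 (0.42 log units; beyond the scatter) as the estimated step. Compound 4 is estimated at 5000 nM in this assay, within a range from 2500 nM to 10000 nM.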

Compound 4, concentration for 50% growth inhibition: 8690 nM
Compound 4: the middle estimate sits 1.7-fold (0.24 log units) below what was measured; the measured number falls inside the stated range.
By their numbers in this assay, from the lowest: compounds 2, 1, 4 and 3 (each within the scatter of the next, the first and the last beyond it).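

In this assay, the exchange of 4-methoxyphenyl for 4-chlorophenyl gives a 1.5-fold lower number from compound 3 to compound 4 (0.18 log units; within the scatter) and chloro in place of hydrogen gives a 1.3-fold higher number from compound 1 to compound 4 (0.11 log units; within the scatter), so hydrogen, methoxy and chloro at this position, para to a large group, cannot be told apart on this core. For the compounds shown here, the one new step beyond the scatter lies at the other aryl group, where, with the 4-chlorophenyl held fixed, 4-hydroxy-3-methoxyphenyl in place of 3-hydroxyphenyl gives a 2.1-fold higher number from compound 2 to compound 4 (0.33 log units; beyond the scatter), a modest difference. No evidence is available to explain these numbers.

The compounds shown leave open whether an amine, a carboxylic acid or a longer chain at this position would shift the number beyond the scatter. They also leave open whether the step between the two hydroxyphenyl groups holds with hydrogen or methoxy in place of chloro.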